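Replacing the aryl group on the ring nitrogen: expected cytotoxicity

A few compounds are considered here, and "the series" means these few. Any claim that something is new, unique, unknown or untested is made for them only; others in the source may bear on it.

Measured compounds:
- compound 1 `N#Cc1ccccc1-n1cc(COc2cccc(NC(=O)Nc3ccc(Cl)c(C(F)(F)F)c3)c2)nn1`, in a toxicity assay on MRC5 cells (Homo sapiens) for inhibition, read by MTT assay, with a stated time of 72 h (on this read-out lower numbers stand for stronger inhibition and higher numbers for weaker inhibition), compound 1 gives 17500 nM
- compound 2 `CC(C)c1cccc(-n2cc(COc3cccc(NC(=O)Nc4ccc(Cl)c(C(F)(F)F)c4)c3)nn2)c1`, in this assay compound 2 gives 21400 nM
- compound 3 `O=C(Nc1cccc(OCc2cn(-c3cccc(Br)c3)nn2)c1)Nc1ccc(Cl)c(C(F)(F)F)c1`, in this assay compound 3 gives 11900 nM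

Compound 2 holds the highest of the three numbers, yet neither step that touches it reaches beyond the scatter: a 1.2-fold higher number from compound 1 to compound 2 (0.09 log units; within the scatter) and a 1.8-fold lower number from compound 2 to compound 3 (0.25 log units; within the scatter). The third pair behaves the same way, a 1.5-fold lower number from compound 1 to compound 3 (0.17 log units; within the scatter). So far, three different aryl groups on the ring nitrogen of the shared core have left the read-out essentially unchanged.

Compound 4 `O=C(Nc1cccc(OCc2cn(-c3ccccc3I)nn2)c1)Nc1ccc(Cl)c(C(F)(F)F)c1` is the next variation. Its change from compound 2 is 2-iodophenyl in place of 3-isopropylphenyl on an aromatic nitrogen. Among the compounds with values here, two measured steps bear on it: the step that put the 3-isopropylphenyl group in place, a 1.2-fold higher number from compound 1 to compound 2 (0.09 log units; within the scatter), and the step that exchanged the isopropyl substituent for a halogen, a 1.8-fold lower number from compound 2 to compound 3 (0.25 log units; within the scatter); both were small and within the scatter. Within the data shown here, nothing among the measured compounds suggests that the new aryl group should move the number noticeably in either direction.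

The estimate for compound 4 in this assay is therefore 16000 nM, with a range from 8000 nM to 35000 nM, which is expected to amount to a 1.3-fold lower number from compound 2 to compound 4 (0.13 log units; within the scatter), a step not expected to exceed the scatter.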

Compound 4, half-maximal inhibitory concentration: 21900 nM
The estimate for compound 4 lay 1.4-fold (0.14 log units) below the measured number; low and high end bracket the measured number.
By their numbers in this assay, from the lowest: compounds 3, 1, 2 and 4 (each within the scatter of the next).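

The new step replaces a nitrile with an iodo on the same phenyl ring, and in this assay it gives a 1.3-fold higher number from compound 1 to compound 4 (0.10 log units; within the scatter), so this exchange of substituent leaves the read-out within the scatter. Exchanging the whole aryl group behaves alike: 2-iodophenyl for 3-isopropylphenyl gives a 1.0-fold higher number from compound 2 to compound 4 (0.01 log units; within the scatter), even though the substituent changes in both kind and ring position, and 2-iodophenyl for 3-bromophenyl gives a 1.8-fold higher number from compound 3 to compound 4 (0.26 log units; within the scatter), a comparison of two halogen-bearing aryl groups. Nothing measured here explains why these exchanges make so little difference to the number.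

Going by these compounds, all four compounds carry a phenyl ring with one substituent on the ring nitrogen, so it remains open whether the number would stay in the same range with a phenyl ring bearing an amine or a carboxylic acid, or with a saturated group such as cyclohexyl or a longer alkyl chain. The chloro and trifluoromethyl groups at the far end of the shared core are also the same throughout, so these compounds say nothing about how replacing them would affect the read-out.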